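This account rests on a few compounds, and the source may have more. Where it says the series, first, only, none or still open, it means among the compounds named here.

Measured so far: compound 3 `CC(C)N(C)c1sc(C(=O)c2ccc(Cl)s2)c(N)c1C#N` gives 1420 nM in an assay for inhibition of Maternal embryonic leucine zipper kinase (Homo sapiens), read by ADP-Glo, with a stated time of 0.5 h; a lower number here means a stronger inhibitor, a higher number a weaker inhibitor; compound 1 `CC(C)Nc1sc(C(=O)c2ccco2)c(N)c1C#N` gives 1350 nM; compound 2 `CC(C)Nc1sc(C(=O)c2ccc(Br)s2)c(N)c1C#N` gives 122 nM.

Compound 3 has the highest number of the three, close to compound 1 and well apart from compound 2. Among the compounds with values here, the only single-place step available, an 11-fold lower number from compound 1 to compound 2 (1.04 log units; beyond the scatter), concerns the group on the carbonyl carbon, not the site changed here. Compound 4 `C=CCNc1sc(C(=O)c2ccc(Cl)s2)c(N)c1C#N` is compound 3 with allylamino in place of isopropyl(methyl)amino on an aromatic carbon. Within the data shown here, no measured step covers this change. Compound 2 and compound 3 differ at two places, so their values only hint that a change at this position can matter. Compound 4 is expected to reach 300 nM (range 80 nM to 1200 nM), a step of a 4.7-fold lower number from compound 3 to compound 4 (0.68 log units; beyond the scatter), though this expectation rests on no direct comparison.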

Compound 4, half-maximal inhibitory concentration: 638 nM
For compound 4 the middle estimate is 2.1-fold (0.33 log units) below the measured one, and the stated range covers the measured number.
By their numbers in this assay, from the lowest: compound 2; then compound 4; then compounds 1 and 3 (each within the scatter of the next).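

Within the data shown here, the earlier compounds gave no step at this position, the aromatic carbon next to the ring sulfur, and this is the first one: allylamino in place of isopropyl(methyl)amino gives a 2.2-fold lower number from compound 3 to compound 4 (0.35 log units; beyond the scatter) here. The swap changes more than one thing at once, since allylamino brings a hydrogen-bond donor and a double bond that isopropyl(methyl)amino lacks, so the step cannot show which of these matters. Nothing available explains the step. Still open, on these data alone, is how a plain amino group or a longer chain such as butylamino would compare at this position.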